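Propargyloxy in place of 4-fluorophenoxy on the chromanone series

The source may report more compounds than this note shows. Statements on the series, on what has been measured and on what is new or still open speak of the compounds shown alone.

Measured so far:
compound 1 `COc1cc2c(cc1CC=C(C)C)/C(=N/NC(N)=O)C[C@@H](c1ccc(O)cc1)O2`, 77%
compound 2 `COc1cc2c(cc1CC=C(C)C)C(=O)C[C@@H](c1ccc(Oc3ccc(F)cc3)cc1)O2`, 27%
compound 3 `COc1ccc([C@@H]2C/C(=N/O)c3cc(CC=C(C)C)c(OC)cc3O2)cc1`, 66%

In a functional assay on A549 cells (Homo sapiens) for inhibition, read by sulforhodamine B assay, with a stated time of 48 h, tested at 50 uM (a lower number here means less inhibition of growth, a higher number more inhibition of growth at the concentration tested), compound 2 gives 27%, the lowest of the three numbers. The nearest is compound 3 with 66%, a gap beyond the scatter; the furthest is compound 1 with 77%, also beyond the scatter. Compound 2 is therefore the least active of the three in this assay on the numbers shown. For the measured compounds named here, no pair among the three differs in a single place, so no measured step is available to anchor the next change.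

Compound 4 `C#CCOc1ccc([C@@H]2CC(=O)c3cc(CC=C(C)C)c(OC)cc3O2)cc1` is not yet measured in this assay. Relative to compound 2 the change is propargyl in place of 4-fluorophenyl on an oxygen on an aromatic ring. The two compounds share the ketone core; compound 1 and compound 3 carry other groups on the same carbon and at the same oxygen, so their values bear only loosely on compound 4.

The step from compound 2 to compound 4 is expected to be a modest rise, a number 15 percentage points higher from compound 2 to compound 4 (beyond the scatter), with wide uncertainty. Compound 4 is thus estimated at 42%, between 15% and 70%.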

Compound 4, percent growth inhibition at one concentration: 53%
Compound 4: the middle estimate sits 11 percentage points below what was measured, and the stated range covers the measured number.
By their numbers in this assay, from the lowest: compound 2; then compound 4; then compound 3; then compound 1.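

In this assay, for the compounds shown here, the change from 4-fluorophenoxy to propargyloxy on the shared core gives a number 26 percentage points higher from compound 2 to compound 4 (beyond the scatter) and is the first step that can be read at a single place. At this oxygen on an aromatic ring, the 4-fluorophenyl group with its aromatic ring is therefore not required for growth inhibition at the concentration tested, since propargyl, with no ring and 3 heavy atoms, gives the higher number. No measurement shown bears on the reason for this step.

As far as these compounds go, whether the gain follows the triple bond or the loss of the aromatic ring stays open; a saturated propyl chain or a benzyl group on the same oxygen would separate the two. Steps from compound 4 to compound 1 or compound 3 cannot be read, as each pair differs in more than one place.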